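The source may report more compounds than this note shows. Statements on the series, on what has been measured and on what is new or still open speak of the compounds shown alone.

Measured compounds in the series:
Compound 1 `COc1ccc(C(C)NC(=O)/N=C(\N)NCCCc2sc(N)nc2C)cc1` gives 37.2 nM in an assay on membranes from Sf9 cells for displacement of a labelled ligand from histamine H2 receptor (Homo sapiens), read by scintillation counting, with a stated time of 60 min; a higher number here means a weaker inhibitor, a lower number a stronger inhibitor.
Compound 2 `Cc1nc(N)sc1CCCN/C(N)=N/C(=O)NC(C)c1ccccc1F` gives 28.8 nM in this assay.
Compound 3 `Cc1nc(N)sc1CCCN/C(N)=N/C(=O)NC(C)c1ccc(Cl)cc1` gives 46.8 nM in this assay.

Compound 3 carries the highest of the three numbers, yet neither gap to the others exceeds the scatter: a 1.3-fold higher number from compound 1 to compound 3 (0.10 log units; within the scatter) and a 1.6-fold higher number from compound 2 to compound 3 (0.21 log units; within the scatter). The three compounds share one core and differ only in the substituent on the aryl ring attached to the saturated chain carbon bound to the amide-type nitrogen; the remaining comparison, a 1.3-fold lower number from compound 1 to compound 2 (0.11 log units; within the scatter), also stays within the scatter. On the present numbers the three aryl variants are indistinguishable in this assay.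

Compound 4 `Cc1nc(N)sc1CCCN/C(N)=N/C(=O)NC(C)c1ccc(F)cc1` has not yet been measured in this assay. Relative to compound 3 the change is fluoro in place of chloro on an aromatic carbon. The two steps that bear on this, both altering the same aryl substituent, are a 1.3-fold higher number from compound 1 to compound 3 (0.10 log units; within the scatter) and a 1.6-fold higher number from compound 2 to compound 3 (0.21 log units; within the scatter); both lie within the scatter, and the exchange of one halogen for another at the same position is a smaller structural move than either. The step from compound 3 to compound 4 is therefore expected to stay within the scatter, a 1.2-fold lower number from compound 3 to compound 4 (0.07 log units; within the scatter). For compound 4 the estimate in this assay is 40 nM, with a range from 20 nM to 80 nM.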

Compound 4, inhibition constant: 31.6 nM
The estimate for compound 4 lay 1.3-fold (0.10 log units) above the measured number; low and high end bracket the measured number.
By their numbers in this assay, from the lowest: compounds 2, 4, 1 and 3 (each within the scatter of the next).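

Fluoro in place of chloro on this aromatic carbon, para to a large group, is the only direct exchange of one halogen for another at a single place in the series, and in this assay it reads as a 1.5-fold lower number from compound 3 to compound 4 (0.17 log units; within the scatter) and so stays within the scatter. Compound 4 also separates the place of the fluoro from its presence: the shift from 2-fluorophenyl to 4-fluorophenyl reads as a 1.1-fold higher number from compound 2 to compound 4 (0.04 log units; within the scatter), while fluoro in place of methoxy at the position held by the 4-substituent reads as a 1.2-fold lower number from compound 1 to compound 4 (0.07 log units; within the scatter), so neither change moves the number beyond the scatter. No available evidence accounts for the size of these steps.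

The series leaves open whether this para place accepts groups of another kind, such as a carboxylic acid, an amine or a trifluoromethyl, with the number staying within the same scatter, and whether a plain phenyl with only hydrogen there would read alike. On these data alone, all four compounds also share the methyl on the saturated chain carbon bound to the amide-type nitrogen, so the outcome of replacing it with hydrogen or an ethyl remains unknown.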